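Swapping the hydroxyethyl pyrazole for a fluorinated ester phenyl

The compounds below may be only part of what the source reports. "The series", "measured", "known", "first", "only" and "open" are said of these compounds alone.

Compound 2 `CC(c1c(F)cc2ncccc2c1F)n1cnc2ncc(-c3cnn(CCO)c3)nc21` gives 2 uL/min in an ADME assay on microsomes from liver (Homo sapiens) for metabolic stability, read by LC-MS, using NADPH, with stated times of 5 min and 30 min, tested at 1 uM (a lower number here means slower removal, a higher number faster removal of the compound), the lowest of the three numbers measured; compound 1 `CC(c1c(F)cc2ncccc2c1F)n1cnc2ncc(-c3cnn(C)c3)nc21` gives 11 uL/min and compound 3 `COC(=O)c1ccc(-c2cnc3ncn(C(C)c4cc5cccnc5cc4F)c3n2)cc1F` gives 73 uL/min. Going by the values given here, the one step measured, a 5.5-fold lower number from compound 1 to compound 2 (0.74 log units; beyond the scatter), concerns a different change. Compound 4 `COC(=O)c1ccc(-c2cnc3ncn(C(C)c4c(F)cc5ncccc5c4F)c3n2)cc1F` carries 3-fluoro-4-(methoxycarbonyl)phenyl in place of 1-(2-hydroxyethyl)-1H-pyrazol-4-yl on an aromatic carbon. Among the compounds with values here, no measured step covers this swap directly, but compound 3 bears the same 3-fluoro-4-(methoxycarbonyl)phenyl group on a closely related core and shows 73 uL/min, whereas compound 2 with its 1-(2-hydroxyethyl)-1H-pyrazol-4-yl shows 2 uL/min. A large rise is therefore expected, a 30-fold higher number from compound 2 to compound 4 (1.48 log units; beyond the scatter). Compound 4 is estimated at 60 uL/min, within a range of 25 uL/min to 150 uL/min.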

Compound 4, intrinsic clearance in a liver preparation (reported as CLH), per the amount of preparation that the assay uses: 290 uL/min
Beside the measured number, compound 4's estimate is 4.8-fold (0.68 log units) below it; the whole stated range lies below it.
By their numbers in this assay, from the lowest: compound 2; then compound 1; then compound 3; then compound 4.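

At this aromatic carbon, the group present moves the number in this assay further than the earlier step did: 3-fluoro-4-(methoxycarbonyl)phenyl in place of 1-(2-hydroxyethyl)-1H-pyrazol-4-yl gives a large rise (a 150-fold higher number from compound 2 to compound 4 (2.16 log units; beyond the scatter)), and in place of 1-methyl-1H-pyrazol-4-yl a similarly large one (a 26-fold higher number from compound 1 to compound 4 (1.42 log units; beyond the scatter)). With that ester phenyl in place, fluoro in place of hydrogen on an aromatic carbon of the other end of the molecule also raises the number (a 4.0-fold higher number from compound 3 to compound 4 (0.60 log units; beyond the scatter)). Nothing shown gives a cause for these steps. As far as these compounds go, whether a carboxylic acid or an amide in place of the methyl ester would bring the number down remains open.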